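The source may hold more compounds than are shown below. What is called first, only, known or untested is meant among the compounds shown, and "the series" means these compounds.

Measured so far in a functional assay on the whole organism (strain Kunming) with Mus musculus as the target, with a stated time of 0.5 h; a lower number here means that less compound is needed, a higher number that more compound is needed for the effect:

- compound 1 `COc1cc(OC)c(OC)cc1/C=C/COC(=O)/C=C/c1ccc(Br)cc1`: 61.8 mg/kg
- compound 2 `COc1cc(OC)c(OC)cc1/C=C/COC(=O)/C=C/c1cc(OC)c(OC)c(OC)c1`: 33.2 mg/kg
- compound 3 `COc1cc(OC)c(OC)cc1/C=C/COC(=O)/C=C/c1ccc(OC)c(OC)c1OC`: 33.4 mg/kg

Compound 1 lies within the usual scatter of both compound 2 and compound 3, so these three values cannot be put in a firm order. Repeat measurements in a whole animal vary enough that gaps of this size may mean nothing.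

The next compound to be tested is compound 4 `COc1cc(OC)c(OC)cc1/C=C/COC(=O)/C=C/c1ccccc1Cl`. It keeps the core of compound 1 and changes one group: 2-chlorophenyl in place of 4-bromophenyl on a double-bonded chain carbon bound to a double-bonded chain carbon. In words, 2-chlorophenyl stands in place of 4-bromophenyl on a double-bonded chain carbon bound to a double-bonded chain carbon.

Among the measured compounds shown here, no two measured compounds differ in one place only, so the data give no direct measure of what a swap like this does. For the measured compounds named here, the only guide is the narrow spread of the series, with compound 1 at 61.8 mg/kg and compound 2 at 33.2 mg/kg. On that basis, no change beyond the scatter is expected. The expected 1.2-fold lower number from compound 1 to compound 4 (0.09 log units; within the scatter) is therefore small, and its direction is uncertain.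

For compound 4 the estimated value is 50 mg/kg, with an expected range of 25 mg/kg to 100 mg/kg.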

Compound 4, dose for half-maximal effect: 58.7 mg/kg
Compound 4: middle estimate off by 1.2-fold (0.07 log units), on the low side, and the stated range covers the measured number.
By their numbers in this assay, from the lowest: compounds 2, 3, 4 and 1 (each within the scatter of the next).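

In this assay, putting 2-chlorophenyl in place of 4-bromophenyl on a double-bonded chain carbon bound to a double-bonded chain carbon gives a 1.1-fold lower number from compound 1 to compound 4 (0.02 log units; within the scatter), so the two compounds cannot be told apart. Among the compounds shown here, this is the first direct reading of a single-place swap, and it shows that this particular exchange of one halogen-bearing phenyl group for another leaves no measurable mark on the dose needed in the whole animal. The swap alters both the halogen and its place on the ring at once, so this one step cannot show whether each alteration alone would also go unseen, and no measurement is available that would explain the result.

On these data alone, it remains open whether this position tolerates any group, or only halogen-bearing phenyl groups of this kind, since a phenyl ring carrying an amine or a carboxylic acid, or a plain phenyl ring with no halogen, might give a number beyond the scatter. The compounds shown also leave open what a change elsewhere, such as a longer chain between the ester and the shared core, would do.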